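Three Analogues at the Limit and an Untested Fourth

A few compounds are considered here, and "the series" means these few. Any claim that something is new, unique, unknown or untested is made for them only; others in the source may bear on it.

Compound 3 `Cc1nc(Nc2ccc(Cl)cc2)sc1C(=O)/C=C/c1ccc(Cl)cc1` is one of three compounds that share the same core and differ only in the aromatic rings hung on its two ends. In a functional assay on NCI-H460 cells (Homo sapiens) for cytotoxicity, read by MTT assay (on this read-out higher numbers stand for weaker inhibition and lower numbers for stronger inhibition), compound 3 gives > 25000 nM, which is a limit of the assay rather than a number. Compound 1 `COc1cccc(/C=C/C(=O)c2sc(Nc3cccc(C)c3)nc2C)c1` stands at the same limit: in this assay compound 1 gives > 25000 nM. Compound 2 `Cc1cccc(Nc2nc(C)c(C(=O)/C=C/c3ccccc3Cl)s2)c1` likewise reaches only the limit, and in this assay compound 2 gives > 25000 nM. Among the measured compounds shown here, the one step that can be traced between measured compounds, a step that the two limits leave unreadable from compound 1 to compound 2, thus cannot be read, as both ends sit at the limit (the limit of > 25000 nM in this assay, at which 3 of the 3 values shown sit).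

Compound 4 `Cc1cccc(Nc2nc(C)c(C(=O)/C=C/c3ccc(Cl)cc3)s2)c1` has not yet been measured. It differs from compound 3 by 3-methylphenyl in place of 4-chlorophenyl on a nitrogen on an aromatic ring. For the measured compounds named here, no measured step touches this change, and every value so far sits at the limit. The step expected here, a step that the limit leaves unreadable from compound 3 to compound 4, is no change beyond the scatter, with compound 4 expected to remain at the limit as well. Compound 4 is accordingly estimated at 35000 nM in this assay, within a range from 10000 nM to 120000 nM, the most likely outcome being another limit rather than a number.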

Compound 4, half-maximal inhibitory concentration: > 25000 nM
Compound 4 gave a limit, no number (the forecaster's own chance of this, stated with the estimate: 80%); the middle value is on the limit's open side.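

In this assay compound 4 gives > 25000 nM, which is a limit of the assay and not a number. Its steps from compound 1, compound 2 and compound 3 therefore cannot be read: the limit of > 25000 nM in this assay, at which 4 of the 4 values shown sit. The compounds shown leave open whether any change to the aromatic rings on the shared core would give a measurable value in this assay.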